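The source may report more compounds than this note shows. Statements on the series, on what has been measured and on what is new or still open speak of the compounds shown alone.

Compound 3 `O=C1O[C@@H](Cn2ccnc2)CN1c1ccc(-n2cc(-c3ccccn3)cn2)c(F)c1` was tested in an ADME assay on HEK293-A cells (Homo sapiens) for cytotoxicity, read by MTT assay, with a stated time of 48 h; on this read-out higher numbers stand for weaker inhibition and lower numbers for stronger inhibition. In this assay compound 3 reaches only the limit, giving > 400 ug/mL. Two further compounds share this outcome. Compound 1 `O=C1CCC(=O)N1C[C@H]1CN(c2ccc(-n3cc(-c4ccccn4)cn3)c(F)c2)C(=O)O1` gives > 400 ug/mL, a limit of the assay. Compound 2 `CC(=O)OC[C@H]1CN(c2ccc(-n3cc(-c4ccccn4)cn3)c(F)c2)C(=O)O1` gives > 400 ug/mL, also a limit. Thus the limit of > 400 ug/mL in this assay, at which 3 of the 3 values shown sit, covers every value known here. The step that the two limits leave unreadable from compound 1 to compound 2 has no readable size, and the same holds for a step that the two limits leave unreadable from compound 1 to compound 3 and for a step that the two limits leave unreadable from compound 2 to compound 3. Among the compounds with values here, compound 3 therefore stands at the limit, level with the other two as far as the numbers can tell, with no step among the three that can be read.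

Compound 4 `CCNC(=O)NC[C@H]1CN(c2ccc(-n3cc(-c4ccccn4)cn3)c(F)c2)C(=O)O1` has not yet been measured. It differs from compound 3 in one place: (ethylcarbamoyl)amino in place of 1H-imidazol-1-yl on a saturated chain carbon bound to a saturated ring carbon. Since none of the three measured steps gives a readable size, no step beyond the scatter can be expected in either direction in this assay. Compound 4 is therefore expected to show a step of a number no higher from compound 3 to compound 4 (the limit leaves the size open). The value of compound 4 is estimated at about 400 ug/mL, within a range from 150 ug/mL to 1000 ug/mL, and most likely it will again be reported as a limit rather than as a number.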

Compound 4, half-maximal inhibitory concentration: 29 ug/mL
Compound 4: the middle estimate sits 14-fold (1.14 log units) above what was measured, and the stated range ends above it.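

In this assay, the place on a saturated chain carbon bound to a saturated ring carbon now proves able to move the read-out: (ethylcarbamoyl)amino in place of 1H-imidazol-1-yl gives an at least 13-fold lower number from compound 3 to compound 4 (1.13 log units; beyond the scatter), in place of acetoxy it gives an at least 13-fold lower number from compound 2 to compound 4 (1.13 log units; beyond the scatter), and in place of 2,5-dioxopyrrolidin-1-yl it gives an at least 13-fold lower number from compound 1 to compound 4 (1.13 log units; beyond the scatter). Within the data shown here, the steps among the three earlier compounds cannot be read, because those compounds gave no number to compare, and so they could not show whether a change at this place matters at all: the limit of > 400 ug/mL in this assay, at which 3 of the 4 values shown sit. Each of the new sizes is a minimum, as the upper end of each step is a limit, and compound 4 is the only one of the four compounds with a number.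

The compounds shown do not tell whether the lower number goes with the ethyl chain, the carbonyl or the hydrogen-bond donors of the entering group. From the compounds shown here alone, it also remains open where a plain amine at this place would fall, or a (propylcarbamoyl)amino group with its longer chain.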